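This account rests on a few compounds, and the source may have more. Where it says the series, first, only, none or still open, it means among the compounds named here.

Measured in a functional assay on MDA-MB-231 cells (Homo sapiens) for inhibition, read by MTT assay, with a stated time of 72 h; a lower number here means a stronger inhibitor, a higher number a weaker inhibitor:
- Compound 1 `COc1ccccc1-c1csc2cnc(Nc3ccc(NC(=O)C4CCNCC4)cc3)nc12`: 1050 nM
- Compound 2 `COc1ccccc1-c1csc2cnc(Nc3ccc(NC(=O)CN)cc3)nc12`: 2770 nM

Compound 2 has the higher of these two numbers, which makes it the weaker inhibitor of the pair. Compound 3 `COc1ccccc1-c1csc2cnc(Nc3ccc(C(=O)NC4CCNCC4)cc3)nc12` has not yet been measured. It differs from compound 2 as follows: (piperidin-4-yl)carbamoyl in place of ((aminomethyl)carbonyl)amino on an aromatic carbon. In words, (piperidin-4-yl)carbamoyl stands in place of ((aminomethyl)carbonyl)amino on an aromatic carbon.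

Among the compounds with values here, only one measured step bears on this change: a 2.6-fold higher number from compound 1 to compound 2 (0.42 log units; beyond the scatter). There, aminomethyl replaced piperidin-4-yl on a carbonyl carbon. Read in reverse, this step points to a modest fall in the number on regaining the ring. However, the amide in compound 3 is attached differently, so this is only a loose guide. The expected change is a 2.0-fold lower number from compound 2 to compound 3 (0.30 log units; within the scatter). For compound 3 the estimated value in this assay is 1400 nM, with an expected range of 500 nM to 3800 nM.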

Compound 3, half-maximal inhibitory concentration: 110 nM
The estimate for compound 3 lay 13-fold (1.10 log units) above the measured number; the whole stated range lies above it.
By their numbers in this assay, from the lowest: compound 3; then compound 1; then compound 2.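

In this assay, this position proves far more sensitive than the earlier pair suggested. With the piperidin-4-yl ring kept, having (piperidin-4-yl)carbamoyl in place of ((piperidin-4-yl)carbonyl)amino on the aromatic carbon, so that the amide runs the other way, gives a 9.5-fold lower number from compound 1 to compound 3 (0.98 log units; beyond the scatter), while the whole change from the smaller group gives a 25-fold lower number from compound 2 to compound 3 (1.40 log units; beyond the scatter); regaining the ring alone therefore cannot account for the size of this step, as the earlier ring change gave only a 2.6-fold higher number from compound 1 to compound 2 (0.42 log units; beyond the scatter). No measurement available here explains why the direction of the amide matters.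

The compounds shown leave open whether the ring nitrogen is needed, which a cyclohexyl ring in its place would test. They also leave open whether an open aminoethyl chain on the carbamoyl nitrogen could stand in for the piperidine ring.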